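The source may hold more compounds than are shown below. What is called first, only, known or untested is meant among the compounds shown, and "the series" means these compounds.

Compound 2 `COc1ccc(-c2cc3ccccc3nc2/C=C/C(=O)c2ccc(N)cc2)cc1` carries a 4-aminophenyl group on the carbonyl carbon. Within the data shown here, in a functional assay on H184B5F5/M10 cells (Homo sapiens) for antiproliferative activity, read by XTT assay, with a stated time of 72 h (on this read-out lower numbers stand for stronger inhibition and higher numbers for weaker inhibition), compound 2 gives 9290 nM, the higher of the two numbers known so far. Among the measured compounds shown here, its only neighbour is compound 1 `COc1ccc(-c2cc3ccccc3nc2/C=C/C(=O)c2ccc(O)cc2)cc1`, which in this assay gives 5690 nM. The step of a 1.6-fold higher number from compound 1 to compound 2 (0.21 log units; within the scatter) lies within the scatter, so the two cannot be ranked. Compound 3 `COc1ccc(-c2cc3ccccc3nc2/C=C/C(=O)c2ccco2)cc1` has not yet been measured. The change is furan-2-yl in place of 4-aminophenyl on a carbonyl carbon. For the measured compounds named here, no measured step concerns an exchange of this kind: the only step recorded, a 1.6-fold higher number from compound 1 to compound 2 (0.21 log units; within the scatter), swaps hydroxy for amino and stays within the scatter, and it gives no direction for replacing a six-membered ring by a five-membered one. The step of a 1.0-fold lower number from compound 2 to compound 3 (0.01 log units; within the scatter) is therefore expected to stay within the scatter, with a wide range. The estimate for compound 3 in this assay is 9000 nM, between 3000 nM and 27000 nM.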

Compound 3, half-maximal inhibitory concentration: 6240 nM
Compound 3: the middle estimate sits 1.4-fold (0.16 log units) above what was measured; the range from low to high includes it.
By their numbers in this assay, from the lowest: compounds 1, 3 and 2 (each within the scatter of the next).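

In this assay, putting furan-2-yl on the carbonyl carbon gives a 1.5-fold lower number from compound 2 to compound 3 (0.17 log units; within the scatter), and against the 4-hydroxyphenyl group it gives a 1.1-fold higher number from compound 1 to compound 3 (0.04 log units; within the scatter). The earlier pair compared only hydroxy with amino on the same six-membered ring, whereas this result reaches the ring itself: a five-membered aromatic ring with an oxygen cannot be told apart from either six-membered ring in this read-out. Losing the hydrogen-bond donor of the 4-aminophenyl group also leaves no readable difference here.

As far as these compounds go, whether a group without an aromatic ring on the carbonyl carbon, such as methyl, a longer alkyl chain or a piperidine ring, would also stay within the scatter remains open. Nothing measured alongside these compounds explains why their values lie so close together.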